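A few compounds are considered here, and "the series" means these few. Any claim that something is new, unique, unknown or untested is made for them only; others in the source may bear on it.

Compound 3 `C[C@H]1CC[C@@H]2[C@@H](OC(=O)[C@]23CC(c2ccccc2)=NO3)[C@]2(C)C(=O)C=C[C@@]12O` sits at the bottom of the three compounds in a physicochemical assay for lipophilicity (on this read-out lower numbers stand for lower lipophilicity and higher numbers for higher lipophilicity), giving 1.41. Compound 2 `C[C@H]1CC[C@@H]2[C@@H](OC(=O)[C@]23CC(c2ccc(Cl)cc2)=NO3)[C@]2(C)C(=O)C=C[C@@]12O` gives 2.09, and compound 1 `C[C@H]1CC[C@@H]2[C@@H](OC(=O)[C@]23CC(c2c(Cl)cccc2Cl)=NO3)[C@]2(C)C(=O)C=C[C@@]12O` gives 2.67; the steps of a number 0.68 log units lower from compound 2 to compound 3 (beyond the scatter) and a number 1.26 log units lower from compound 1 to compound 3 (beyond the scatter) show that removing chloro from the phenyl ring lowers the number. Compound 4 `COc1ccc(C2=NO[C@]3(C2)C(=O)O[C@@H]2[C@H]3CC[C@H](C)[C@]3(O)C=CC(=O)[C@@]23C)cc1OC` carries a different change: 3,4-dimethoxyphenyl in place of phenyl on a carbon with a double bond to nitrogen. Among the compounds with values here, no measured step here exchanges phenyl for a group bearing methoxy, so the chloro steps bear only loosely on it. For compound 4 the step of a number 0.04 log units higher from compound 3 to compound 4 (within the scatter) is expected to stay within the scatter. Compound 4 is therefore estimated at 1.45, with a range from 1 to 1.9.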

Compound 4, partition coefficient: 1.06
The estimate for compound 4 lay 0.39 log units above the measured number; the range from low to high includes it.
By their numbers in this assay, from the lowest: compound 4; then compound 3; then compound 2; then compound 1.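

Placing 3,4-dimethoxyphenyl on the carbon with a double bond to nitrogen gives a number 0.35 log units lower from compound 3 to compound 4 (beyond the scatter) in this assay, so a group at this position can also bring the number below that of phenyl, whereas both chloro compounds lie above it. The two chloro rings give larger steps when replaced: a number 1.03 log units lower from compound 2 to compound 4 (beyond the scatter) and a number 1.61 log units lower from compound 1 to compound 4 (beyond the scatter). Nothing available explains these shifts. The compounds shown leave open what a single methoxy group would do here. Going by these compounds, an amine or a carboxylic acid on the phenyl ring also remains untested.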